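Compound 4: chloro in place of methoxy

The source may hold more compounds than are shown below. What is called first, only, known or untested is meant among the compounds shown, and "the series" means these compounds.

In a functional assay on A549 cells (Homo sapiens) for antiproliferative activity, read by MTT assay, with a stated time of 72 h (on this read-out lower numbers stand for stronger inhibition and higher numbers for weaker inhibition), compound 1 `CN1CCN(C(=S)SCc2ccc3nc(N)nc(N)c3c2)CC1` gives 9200 nM, compound 2 `Nc1nc(N)c2cc(CSC(=S)N3CCN(C4CCCCC4)CC3)ccc2n1` gives 4710 nM, and compound 3 `COc1ccc(N2CCN(C(=S)SCc3ccc4nc(N)nc(N)c4c3)CC2)cc1` gives 1590 nM, the lowest of the three numbers. Compound 4 `Nc1nc(N)c2cc(CSC(=S)N3CCN(c4ccc(Cl)cc4)CC3)ccc2n1` has chloro in place of methoxy on an aromatic carbon, para to a large group: chloro in place of methoxy on an aromatic carbon.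

Within the data shown here, no measured step makes this exchange, so the evidence is indirect. The measured steps all alter the whole group on the amine nitrogen in a ring. Placing 4-methoxyphenyl instead of methyl gives a 5.8-fold lower number from compound 1 to compound 3 (0.76 log units; beyond the scatter), and placing it instead of cyclohexyl gives a 3.0-fold lower number from compound 2 to compound 3 (0.47 log units; beyond the scatter). Cyclohexyl instead of methyl gives only a 2.0-fold lower number from compound 1 to compound 2 (0.29 log units; within the scatter). These steps are modest, and the change in compound 4 is smaller than any of them, leaving the six-membered aromatic ring in place. The expected step is therefore none beyond the scatter, with no firm direction: an estimated 1.3-fold higher number from compound 3 to compound 4 (0.10 log units; within the scatter).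

For compound 4 the estimated value is 2000 nM, with an expected range of 750 nM to 5300 nM.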

Compound 4, half-maximal inhibitory concentration: 5210 nM
Beside the measured number, compound 4's estimate is 2.6-fold (0.42 log units) below it; the measured number falls inside the stated range.
By their numbers in this assay, from the lowest: compound 3; then compounds 2, 4 and 1 (each within the scatter of the next).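

In this assay the group on the aromatic carbon para to a large group matters: 4-chlorophenyl in place of 4-methoxyphenyl gives a 3.3-fold higher number from compound 3 to compound 4 (0.52 log units; beyond the scatter), so the standing of compound 3 in this short series does not come from the six-membered aromatic ring alone. Among these compounds, with chloro at this place, the aromatic ring no longer sets the compound apart from those carrying other groups on the amine nitrogen in a ring, with a 1.1-fold higher number from compound 2 to compound 4 (0.04 log units; within the scatter) and a 1.8-fold lower number from compound 1 to compound 4 (0.25 log units; within the scatter). No measurement at hand explains the difference between methoxy and chloro.

The compounds shown leave open whether the lower number of compound 3 is specific to methoxy or would also appear with ethoxy, hydroxy or an amine at the same place. They also leave open whether methoxy would give a similar number elsewhere on the aromatic ring.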